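The compounds below may be only part of what the source reports. "The series", "measured", "known", "first", "only" and "open" are said of these compounds alone.

The measured compounds:
compound 1 `N#Cc1c(-c2ccc(Br)cc2)nc2cnccc2c1NCC(N)=O` gives 1.9
compound 2 `CC[C@@H](Nc1c(C#N)c(-c2ccc(-c3ncccc3C)cc2)nc2cnccc12)C(N)=O` gives 2
compound 3 `CCOc1ccccc1-c1ccc(-c2nc3cnccc3c(N[C@H](CC)C(=O)NS(=O)(=O)C3CC3)c2C#N)cc1` gives 2.3

In a physicochemical assay for lipophilicity, read by HPLC, at pH 7.5 (a higher number here means a more lipophilic compound, a lower number a more polar compound), compound 3 stands at the highest of the three numbers. The nearest is compound 2, whose value of 2 lies within the usual scatter of the value of compound 3; the furthest is compound 1, whose value of 1.9 lies beyond that scatter. Compound 4 `CCOc1ccccc1-c1ccc(-c2nc3cnccc3c(NC(CC)CNS(=O)(=O)C3CC3)c2C#N)cc1` has not yet been measured in this assay. It differs from compound 3 in one place: a group of 11 heavy atoms (7 carbon, 1 nitrogen, 2 oxygen, 1 sulfur; one three-membered non-aromatic ring of carbon only) in place of a group of 12 heavy atoms (7 carbon, 1 nitrogen, 3 oxygen, 1 sulfur; one three-membered non-aromatic ring of carbon only), on a nitrogen on an aromatic ring. Among the measured compounds shown here, no change between two measured compounds at a single place is available, so the coming step has no measured counterpart to lean on. The entering group carries one oxygen, one hydrogen-bond acceptor and one double bond outside aromatic rings fewer than the group it replaces, and a step upward beyond the scatter is expected. Compound 4 is expected to give about 3.3, within a range from 2.6 to 4. The step expected from compound 3 to compound 4 is a number 1.00 log units higher from compound 3 to compound 4 (beyond the scatter).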

Compound 4, distribution coefficient: 3.6
Compound 4: middle estimate off by 0.30 log units, on the low side; low and high end bracket the measured number.
By their numbers in this assay, from the lowest: compounds 1, 2 and 3 (each within the scatter of the next, the first and the last beyond it); then compound 4.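

In this assay, among the compounds shown here, the group of 11 heavy atoms in place of the group of 12 heavy atoms, on a nitrogen on an aromatic ring, gives a number 1.30 log units higher from compound 3 to compound 4 (beyond the scatter) and is the first single-place step in this set. It shows that this position can move the reading well beyond the scatter even when the change is small by count: both groups keep the three-membered carbon ring and 1 hydrogen-bond donor, while the entering group has 2 hydrogen-bond acceptors against 3. Nothing measured here explains the size of this step.

On these data alone, it stays open whether the same swap gives a similar step on another core, and whether the stereocentre matters, as only the leaving group has 1 defined stereocentre. As far as these compounds go, how a carboxylic acid or an amine would read at this place also remains open.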